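Swapping Ethoxy for Dimethylamino on a Carbonyl Carbon

The compounds below may be only part of what the source reports. "The series", "measured", "known", "first", "only" and "open" are said of these compounds alone.

Compound 2 `CCOC(=O)N1CCC(CN2CC[C@H](NC(=O)c3cc(Cl)c(N)cc3OC)[C@H](OC)C2)CC1` carries the shared core of this series with a 1-(ethoxycarbonyl)piperidin-4-yl group. Among the compounds with values here, in an assay on COS-7 cells for displacement of a labelled ligand from 5-hydroxytryptamine receptor 4 (Homo sapiens), read by scintillation counting, with a stated time of 30 min (a lower number here means a stronger inhibitor, a higher number a weaker inhibitor), compound 2 gives 377 nM, the second highest of the three numbers measured so far. Compound 1 `CCCC(=O)N1CCC(CN2CC[C@H](NC(=O)c3cc(Cl)c(N)cc3OC)[C@H](OC)C2)CC1` has propyl where compound 2 has ethoxy on the carbonyl carbon; in this assay compound 1 gives 178 nM, and a 2.1-fold higher number from compound 1 to compound 2 (0.33 log units; beyond the scatter). Compound 3 `CCC(=O)N1CCC(CCN2CC[C@H](NC(=O)c3cc(Cl)c(N)cc3OC)[C@H](OC)C2)CC1` gives 805 nM in this assay; a 2.1-fold higher number from compound 2 to compound 3 (0.33 log units; beyond the scatter), and a 4.5-fold higher number from compound 1 to compound 3 (0.66 log units; beyond the scatter).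

Compound 4 `COc1cc(N)c(Cl)cc1C(=O)N[C@H]1CCN(CC2CCN(C(=O)N(C)C)CC2)C[C@H]1OC` differs from compound 2 in one place: dimethylamino in place of ethoxy on a carbonyl carbon. Within the data shown here, of the measured steps, only the one from compound 1 to compound 2 alters the group on this carbonyl carbon, and that exchange produced only a modest shift. Among the measured compounds shown here, no measured compound carries dimethylamino, so the direction of the present change cannot be read from the data. Compound 4 is therefore expected to land near compound 2, with a step of a 1.2-fold lower number from compound 2 to compound 4 (0.07 log units; within the scatter) expected in this assay. The estimate for compound 4 in this assay is 320 nM, with an expected range from 120 nM to 850 nM.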

Compound 4, half-maximal inhibitory concentration: 52 nM
Beside the measured number, compound 4's estimate is 6.2-fold (0.79 log units) above it, outside the stated range (below it).
By their numbers in this assay, from the lowest: compound 4; then compound 1; then compound 2; then compound 3.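

In this assay, the carbonyl carbon whose other neighbour is the amide-type nitrogen in a ring proves more responsive than the earlier exchange of propyl for ethoxy (a 2.1-fold higher number from compound 1 to compound 2 (0.33 log units; beyond the scatter)) suggested: dimethylamino in place of ethoxy gives a larger shift (a 7.3-fold lower number from compound 2 to compound 4 (0.86 log units; beyond the scatter)), and dimethylamino in place of propyl also lowers the number (a 3.4-fold lower number from compound 1 to compound 4 (0.53 log units; beyond the scatter)). Dimethylamino therefore gives the lowest number of the three groups compared on this carbonyl carbon, with ethoxy giving the highest, and the step from the differently built side group of compound 3 is the largest in the set (a 15-fold lower number from compound 3 to compound 4 (1.19 log units; beyond the scatter)), although that step replaces the whole (1-propanoylpiperidin-4-yl)methyl group and cannot be credited to dimethylamino alone. Nothing available explains why dimethylamino gives the lower number here.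

The compounds shown leave open whether the gain belongs to dimethylamino in particular or extends to other amino groups on this carbonyl carbon, such as methylamino or diethylamino. They also leave open how dimethylamino would read on the side chain of compound 3.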